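This account rests on a few compounds, and the source may have more. Where it says the series, first, only, none or still open, it means among the compounds named here.

Working notes on the series. Within the data shown here, compound 1 `O=C(NNc1nncc2ccccc12)C1CC1c1ccc(OCC(F)(F)F)cc1` is the only member with a number: in a functional assay on MCF7 cells (Homo sapiens) for inhibition, read by MTT assay, with a stated time of 72 h (on this read-out lower numbers stand for stronger inhibition and higher numbers for weaker inhibition), compound 1 gives 8000 nM. Compound 2 `CC(C)=CCOc1ccc(C2CC2C(=O)NNC(=O)c2ccncc2)cc1` was run in this assay and compound 2 gives "not determined" (no result reported). Compound 3 `COc1ccc(C2CC2C(=O)NNC(=O)c2ccncc2)cc1` was also run in this assay and compound 3 gives "not determined" (no result reported). Among the measured compounds shown here, with no result for either of these two, compound 1 cannot be placed against any neighbour, and no step between measured compounds exists here.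

Compound 4 `O=C(NNc1nncc2ccccc12)C1CC1c1ccc(OC(F)(F)F)cc1` is the next entry for this assay. The change from compound 1 is trifluoromethyl in place of 2,2,2-trifluoroethyl on an oxygen on an aromatic ring. For the measured compounds named here, with no measured step to lean on, the expectation is for no step beyond the usual scatter, in either direction; the expected step is no change at the digits printed from compound 1 to compound 4 (within the scatter). For compound 4 the estimate in this assay is 8000 nM, with a range from 3000 nM to 20000 nM.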

Compound 4, half-maximal inhibitory concentration: 54000 nM
Compound 4: the middle estimate sits 6.8-fold (0.83 log units) below what was measured, outside the stated range (above it).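

In this assay the series now has its first measured step, with a 6.8-fold higher number from compound 1 to compound 4 (0.83 log units; beyond the scatter) for trifluoromethyl in place of 2,2,2-trifluoroethyl on an oxygen on an aromatic ring. The higher number stands for weaker inhibition, so this position is not indifferent to the group carried on that oxygen, at least on the core of compound 1. No measured evidence accounts for this step. On these data alone, what a longer chain, an amine or a carboxylic acid would do at this position stays open, as does whether the step holds on any other core.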